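Changing the branched group on the indole nitrogen

The source may hold more compounds than are shown below. What is called first, only, known or untested is meant among the compounds shown, and "the series" means these compounds.

Measured compounds:
- compound 1, `CCCC(C(C)C)n1ccc2cc(/C(C)=C/C(=O)Nc3ccccc3OCCCC(=O)O)ccc21`: 7.2 nM
- compound 2, `CCCCC(CC)n1ccc2cc(/C(C)=C/C(=O)Nc3ccccc3OCCCC(=O)O)ccc21`: 7.1 nM
- compound 3, `CCCCCC(CCCCC)n1ccc2cc(/C(C)=C/C(=O)Nc3ccccc3OCCCC(=O)O)ccc21`: 25 nM

All three compounds share one core and differ only in the group carried on an aromatic nitrogen. In an assay on Prostate gland for inhibition of steroid 5-alpha-reductase (Rattus norvegicus) (on this read-out higher numbers stand for weaker inhibition and lower numbers for stronger inhibition), compound 1 gives 7.2 nM and compound 2 gives 7.1 nM; these two values are within the scatter of each other (a 1.0-fold lower number from compound 1 to compound 2 (0.01 log units; within the scatter)). Compound 3 stands at the highest number of the three, with 25 nM, and both steps to it lie beyond the scatter (a 3.5-fold higher number from compound 1 to compound 3 (0.54 log units; beyond the scatter) and a 3.5-fold higher number from compound 2 to compound 3 (0.55 log units; beyond the scatter)).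

Compound 4, `CCCC(c1ccccc1)n1ccc2cc(/C(C)=C/C(=O)Nc3ccccc3OCCCC(=O)O)ccc21`, has not yet been measured. It differs from compound 3 in one place: 1-phenylbutyl in place of 1-pentylhexyl on an aromatic nitrogen.

The two measured steps that bear on this change both show that replacing a 1-isopropylbutyl or 1-ethylpentyl group by 1-pentylhexyl raised the number in this assay by a modest amount. Compound 4 carries a 1-phenylbutyl group, whose count of heavy atoms lies nearer to the groups of compounds 1 and 2 than to that of compound 3. The expectation is therefore a modest move back toward the lower numbers of compounds 1 and 2, that is, a drop beyond the scatter is expected: a 2.5-fold lower number from compound 3 to compound 4 (0.40 log units; beyond the scatter). For compound 4 a value of about 10 nM is estimated, within a range from 4 nM to 25 nM.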

Compound 4, half-maximal inhibitory concentration: 9.1 nM
Compound 4: the middle estimate sits 1.1-fold (0.04 log units) above what was measured, within the range that was stated.
By their numbers in this assay, from the lowest: compounds 2, 1 and 4 (each within the scatter of the next); then compound 3.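

The nitrogen substituent can carry a six-membered aromatic ring without the number staying at the level of compound 3: in this assay there is a 2.7-fold lower number from compound 3 to compound 4 (0.44 log units; beyond the scatter) when 1-phenylbutyl replaces 1-pentylhexyl. The heavy-atom count changes only slightly in this swap, yet the step lies beyond the scatter, so that count alone does not follow the number for this pair. The ring also sits level with the open-chain groups, as both a 1.3-fold higher number from compound 2 to compound 4 (0.11 log units; within the scatter) and a 1.3-fold higher number from compound 1 to compound 4 (0.10 log units; within the scatter) lie within the scatter, the second being a direct exchange of isopropyl for phenyl on the saturated chain carbon bound to the aromatic nitrogen. No supporting measurement is available to explain these numbers.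

The compounds shown leave open how a fluorine, a methoxy group or an amine on the phenyl ring would change the number in this assay. They also leave open whether a shorter chain, such as the ethyl of a 1-phenylpropyl group, could take the place of the butyl chain that carries the ring.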